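This account rests on a few compounds, and the source may have more. Where it says the series, first, only, none or still open, it means among the compounds named here.

The shared core of this set carries a ribose-like sugar on a purine-type scaffold and a benzylamine arm that varies from compound to compound. Compound 1 `OC[C@H]1O[C@@H](n2cnc3c(NCc4cccc(Br)c4)ncnc32)[C@H](O)[C@@H]1O` and compound 3 `OC[C@H]1O[C@@H](n2cnc3c(NCc4cc(F)cc(F)c4)ncnc32)C(O)C1O` are the two for which a result in a functional assay on G-361 cells (Homo sapiens) for antiproliferative activity, with a stated time of 72 h (a higher number here means a weaker inhibitor, a lower number a stronger inhibitor), is known. In this assay compound 1 gives > 166000 nM, which is a limit of the assay rather than a number. In this assay compound 3 likewise gives > 166000 nM, again a limit. Compound 2 `Cc1ccc(CNc2ncnc3c2ncn3[C@@H]2O[C@H](CO)[C@@H](O)[C@H]2O)cc1` carries the 4-methylphenyl arm, and in this assay compound 2 stands at "not determined" (no result reported), so no number places it at all; the only footing is the limit of > 166000 nM in this assay, at which 2 of the 3 values shown sit.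

Compound 4 `OC[C@H]1O[C@@H](n2cnc3c(NCc4c(F)ccc(F)c4F)ncnc32)[C@H](O)[C@@H]1O` differs from compound 2 by 2,3,6-trifluorophenyl in place of 4-methylphenyl on a saturated chain carbon bound to a nitrogen on an aromatic ring. Within the data shown here, with no measured step to lean on, the size of any change from compound 2 to compound 4 in this assay cannot be stated, and no direction is claimed. Given that both known values sit at the limit, compound 4 is expected to give about 200000 nM, within 100000 nM to 500000 nM, and most likely to be reported only as a limit.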

Compound 4, half-maximal inhibitory concentration: > 166000 nM
Compound 4 was reported as a limit; the forecaster's own chance of this, stated with the estimate: 85%; the middle value lies beyond the limit too.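

In this assay, among these compounds, compound 1 and compound 4 both stand at a limit, so no step between them can be read: the limit of > 166000 nM in this assay, at which 3 of the 4 values shown sit. The compounds shown leave open whether any arm on the shared core would give a number in this assay rather than a limit.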